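Cyclobutyl for cyclopropyl on the ether carbon

The compounds below may be only part of what the source reports. "The series", "measured", "known", "first", "only" and "open" are said of these compounds alone.

Measured compounds:
compound 1 `O=C(O)CCNC(=O)c1ccc(C(Oc2ccc(-n3cc(C(F)(F)F)cn3)cc2)C2CC2)cc1` — 1.7
compound 2 `CCCC(Nc1cnc(-n2cc(C(F)(F)F)cn2)nc1)c1ccc(C(=O)NCCC(=O)O)cc1` — 1.3
compound 3 `CCCC(Oc1cnc(-n2cc(C(F)(F)F)cn2)nc1)c1ccc(C(=O)NCCC(=O)O)cc1` — 1.5

In a physicochemical assay for lipophilicity, using the shake flask method, at pH 7.4 (a higher number here means a more lipophilic compound, a lower number a more polar compound), compound 1 gives 1.7, the highest of the three numbers. Compound 3 gives 1.5, which sits within the scatter of compound 1, so the two cannot be told apart. Compound 2 gives 1.3, a number lower than compound 1 by more than the scatter. For the measured compounds named here, no two of the measured compounds differ in one place only, so no single step is available from them.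

The unmeasured compound 4 `O=C(O)CCNC(=O)c1ccc(C(Oc2ccc(-n3cc(C(F)(F)F)cn3)cc2)C2CCC2)cc1` follows from compound 1 by one change:
cyclobutyl in place of cyclopropyl on a saturated chain carbon bound to an aromatic carbon and an oxygen on an aromatic ring

The ring that leaves and the ring that enters differ only in the counts shown above. In this assay such a step is expected to move the number upward by a small amount, at about the edge of the scatter. Compound 4 is therefore expected to give 2.1, with a range from 1.8 to 2.5. The expected step is a number 0.40 log units higher from compound 1 to compound 4 (beyond the scatter).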

Compound 4, distribution coefficient: 2.6
For compound 4 the middle estimate is 0.50 log units below the measured one; measured number above the stated range.
By their numbers in this assay, from the lowest: compounds 2, 3 and 1 (each within the scatter of the next, the first and the last beyond it); then compound 4.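

In this assay, for the compounds shown here, this position now has its only single-place step, as the earlier compounds all differ from one another in more than one place: cyclobutyl in place of cyclopropyl gives a number 0.90 log units higher from compound 1 to compound 4 (beyond the scatter) and this step lies beyond the scatter. The number at this saturated chain carbon therefore does not stay put when a three-membered carbon ring becomes a four-membered one, even though neither ring carries a hydrogen-bond donor, a hydrogen-bond acceptor or a net charge. Nothing available here accounts for the size of this step.

From the compounds shown here alone, whether the same ring change gives a similar step on the cores of compound 2 and compound 3 stays open. Also open, going by these compounds, is what a cyclopentyl group, an oxetane ring or a longer chain would give at this position.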